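Swapping an Aromatic Ring for a Propyl Chain

The compounds below may be only part of what the source reports. "The series", "measured", "known", "first", "only" and "open" are said of these compounds alone.

Measured so far:
Compound 1, `CC(=O)OC[C@H]1O[C@@H](n2cc(CN3C(=O)/C(=C/c4ccccc4)c4ccccc43)nn2)[C@H](OC(C)=O)[C@@H](OC(C)=O)[C@@H]1OC(C)=O`: 30200 nM
Compound 2, `CC(=O)OC[C@H]1O[C@@H](n2cc(CN3C(=O)/C(=C/c4cccs4)c4ccccc43)nn2)[C@H](OC(C)=O)[C@@H](OC(C)=O)[C@@H]1OC(C)=O`: 28100 nM

Both compounds were tested in a functional assay on MCF7 cells (Homo sapiens) for cytotoxicity, read by sulforhodamine B assay, with a stated time of 48 h; on this read-out higher numbers stand for weaker inhibition and lower numbers for stronger inhibition. Going by the values given here, compound 2 holds the lowest of the two numbers, its only neighbour being compound 1, and the step of a 1.1-fold lower number from compound 1 to compound 2 (0.03 log units; within the scatter) lies within the scatter, so the two cannot be ordered against each other; both sit at a weak level. Compound 3, `CCC/C=C1/C(=O)N(Cc2cn([C@@H]3O[C@H](COC(C)=O)[C@@H](OC(C)=O)[C@H](OC(C)=O)[C@H]3OC(C)=O)nn2)c2ccccc21`, differs from compound 2 in one place: propyl in place of thiophen-2-yl on a double-bonded chain carbon bound to a double-bonded ring carbon. Among the compounds with values here, the single measured step, a 1.1-fold lower number from compound 1 to compound 2 (0.03 log units; within the scatter), exchanged one aromatic ring for another at this same place and changed little. Within the data shown here, it does not show what happens when the ring is replaced by a chain with no ring, so no measured step bears directly on this change. The expectation therefore rests mainly on compound 2 and its weak 28100 nM, and a step of a 1.4-fold higher number from compound 2 to compound 3 (0.13 log units; within the scatter) of modest size is expected, more likely toward a higher number, with a wide range. Compound 3 is thus estimated at 38000 nM, within a range from 12000 nM to 120000 nM.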

Compound 3, half-maximal inhibitory concentration: 22600 nM
Estimate against measurement, compound 3: 1.7-fold (0.23 log units) above; measured number inside the range.
By their numbers in this assay, from the lowest: compounds 3, 2 and 1 (each within the scatter of the next).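

In this assay the exchange for propyl gives a 1.2-fold lower number from compound 2 to compound 3 (0.09 log units; within the scatter) and also a 1.3-fold lower number from compound 1 to compound 3 (0.13 log units; within the scatter) and neither step leaves the scatter, so a chain with no ring cannot be told apart from either aromatic ring at this place. The earlier pair compared only one aromatic ring with another, whereas these steps show that, among these three compounds, an aromatic ring on a double-bonded chain carbon bound to a double-bonded ring carbon is not required for the weak cytotoxicity seen. Nothing measured here explains why the three values lie so close together.

The compounds shown leave open whether any group at this place can move the value beyond the scatter, for instance a longer chain such as octyl, or a propyl chain ending in an amine or a carboxylic acid. They also leave open whether the same closeness of the three values would hold on cells other than the one line tested here.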